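The source may report more compounds than this note shows. Statements on the series, on what has been measured and on what is new or still open speak of the compounds shown alone.

Measured in a functional assay on CHO cells with adenosine receptor A1 (Homo sapiens) as the target, read by cAMP accumulation and immunoassay, with a stated time of 6 min, tested at 0.01 uM; a higher number here means a weaker effect of the compound at the concentration tested, a lower number a stronger effect:
compound 1 `Nc1scc(CN2CCN(c3cc(Cl)cc(Cl)c3)CC2)c1C(=O)c1ccc(Cl)cc1` gives -1%
compound 2 `Nc1scc(CN2CCN(c3ccc(Cl)c(C(F)(F)F)c3)CC2)c1C(=O)c1ccc(Cl)cc1` gives -2.5%
compound 3 `Nc1scc(CN2CCN(c3cccc4ccccc34)CC2)c1C(=O)c1ccc(Cl)cc1` gives 8.7%

Compound 3 holds the highest of the three numbers. Its nearest neighbour is compound 1, within the scatter; its furthest is compound 2, beyond the scatter. The step of a number 9.7 percentage points higher from compound 1 to compound 3 (within the scatter) stays within the scatter, while the step of a number 11.2 percentage points higher from compound 2 to compound 3 (beyond the scatter) goes beyond it and counts as modest. Both of these steps introduce naphthalen-1-yl in place of a substituted phenyl on the amine nitrogen in the ring, so both bear directly on what follows.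

Compound 4 `Nc1scc(CN2CCN(c3cc(F)ccc3F)CC2)c1C(=O)c1ccc(Cl)cc1` has not been measured. 2,5-difluorophenyl in place of naphthalen-1-yl on an amine nitrogen in a ring This exchange runs the other way: the two-ring group leaves and a single substituted ring enters on the same amine nitrogen. Compound 1 and compound 2 each carry such a single substituted ring at that position and sit close to zero, so a downward step of about the size seen in those two comparisons is expected, near the edge of the scatter. For compound 4 in this assay a value of 0% is estimated, with a range from -10% to 11%. The expected step of a number 8.7 percentage points lower from compound 3 to compound 4 (within the scatter) would then be of roughly the size of the measured steps, in the opposite direction.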

Compound 4, a percentage reported as activity, at one concentration (the size of the read-out at that concentration, not a potency): 3.1%
Compound 4: middle estimate off by 3.1 percentage points, on the low side, and the stated range covers the measured number.
By their numbers in this assay, from the lowest: compounds 2, 1, 4 and 3 (each within the scatter of the next, the first and the last beyond it).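

In this assay the step of a number 5.6 percentage points lower from compound 3 to compound 4 (within the scatter) shows that naphthalen-1-yl on the amine nitrogen can be exchanged for 2,5-difluorophenyl, a single ring carrying only fluorine, without a shift beyond the scatter. The steps of a number 5.6 percentage points higher from compound 2 to compound 4 (within the scatter) and a number 4.1 percentage points higher from compound 1 to compound 4 (within the scatter) also stay within the scatter, so compound 4 cannot be told apart from any of the three earlier compounds, even though compound 2 and compound 3 differ from each other beyond it, and this position has so far accommodated chlorine, trifluoromethyl and fluorine substituents and a two-ring group with only modest differences in the number. Nothing available bears on why these steps are so small.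

On these data alone, all four groups at this position are aromatic rings of carbon only, so it remains open whether a pyridin-2-yl ring, a benzyl group or a saturated cyclohexyl ring on the same nitrogen would move the number beyond the scatter. The read-out also comes from a single concentration and gives no potency, so any differences in potency among these compounds remain open.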